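The compounds below may be only part of what the source reports. "The series", "measured", "known", "first", "only" and "open" are said of these compounds alone.

Compound 1 `CN(Cc1ccc2nccn2c1)c1nnc(-c2ccccc2)o1` is the plainest member of this small set. In a physicochemical assay for lipophilicity, at pH 7.4 (a higher number here means a more lipophilic compound, a lower number a more polar compound), compound 1 gives 2.4. Compound 2 `CN(Cc1ccc2nccn2c1)c1nnc(-c2ccc(C3CC3)cc2)o1` carries a cyclopropyl in place of a hydrogen on an aromatic carbon, and in this assay compound 2 gives 3.5; that change is a number 1.10 log units higher from compound 1 to compound 2 (beyond the scatter). Compound 3 `CN(Cc1ccc2nccn2c1)c1nnc(-c2ccc(-c3ccccc3)cc2)o1` carries a phenyl at that position instead, and in this assay compound 3 gives 3.9, the highest of the three numbers: the step is a number 1.50 log units higher from compound 1 to compound 3 (beyond the scatter), and the swap of cyclopropyl for phenyl is a number 0.40 log units higher from compound 2 to compound 3 (beyond the scatter). Compound 4 `CN(Cc1ccc2nccn2c1)c1nnc(-c2ccc(-c3ccccc3F)cc2)o1` differs from compound 3 by fluoro in place of hydrogen on an aromatic carbon, sitting on a six-membered aromatic ring of carbon only, ortho to a large group; seen one bond further out, the phenyl becomes a 2-fluorophenyl. For the measured compounds named here, none of the measured steps is this change: each of them adds or exchanges a whole ring, and their sizes mark how far a single alteration has moved this assay here. The entering group counts only one heavy atom, and a small upward step is expected for compound 4, a number 0.20 log units higher from compound 3 to compound 4 (within the scatter). The estimate for compound 4 in this assay is 4.1, with a range from 3.8 to 4.4.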

Compound 4, distribution coefficient: 4.4
Estimate against measurement, compound 4: 0.30 log units below; measured number inside the range.
By their numbers in this assay, from the lowest: compound 1; then compound 2; then compound 3; then compound 4.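

In this assay, for the compounds shown here, the swap of one hydrogen for fluoro, on an aromatic carbon ortho to a large group, gives a step of its own: a number 0.50 log units higher from compound 3 to compound 4 (beyond the scatter) (a single heavy atom can move this number, where the earlier steps all involved a whole ring). Measured against the smaller groups, 2-fluorophenyl in place of cyclopropyl gives a number 0.90 log units higher from compound 2 to compound 4 (beyond the scatter) and 2-fluorophenyl in place of hydrogen gives a number 2.00 log units higher from compound 1 to compound 4 (beyond the scatter) (compound 4 is therefore the top of the series, with a clear gap to each of the others). Nothing available here explains why fluoro shifts the number this far.

Fluoro is the only substituent shown on the outer ring, and only at this one place. Going by these compounds, whether a chlorine, a methoxy group, an amine or a carboxylic acid there would raise or lower the number remains open.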